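Swapping an Oxygen-Rich Chain for an Aromatic Ring

The source may report more compounds than this note shows. Statements on the series, on what has been measured and on what is new or still open speak of the compounds shown alone.

Measured so far in a functional assay on the whole organism (strain albino) for inhibition, with Rattus norvegicus as the target, read by paw edema, with a stated time of 1 h, at a dose of 20 mmol/kg by the intraperitoneal route; a higher number here means more inhibition at the dose given (going by the name of the read-out), a lower number less inhibition:
compound 1 `N#CC1=C(NCC(=O)N2CCOCC2)N(c2ccccc2)C(=O)N2CCCCC(N3CCCC3)C12` gives 43.9%
compound 2 `N#CC1=C(/N=C/c2ccccc2)N(c2ccccc2)C(=O)N2CCCCC(N3CCCC3)C12` gives 46.5%
compound 3 `CCOC(=O)C(=O)NC1=C(C#N)C2C(N3CCCC3)CCCCN2C(=O)N1c1ccccc1` gives 71.2%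

Compound 3 stands highest of the three numbers in this assay. Its nearest neighbour is compound 2, separated by a number 24.7 percentage points higher from compound 2 to compound 3 (beyond the scatter); the furthest is compound 1, separated by a number 27.3 percentage points higher from compound 1 to compound 3 (beyond the scatter). Compounds 1 and 2 sit within the scatter of one another, so no order can be read between them: a number 2.6 percentage points higher from compound 1 to compound 2 (within the scatter).

The next compound, compound 4 `N#CC1=C(/N=C/Nc2ccccc2)N(c2ccccc2)C(=O)N2CCCCC(N3CCCC3)C12`, is not yet measured. It differs from compound 3 in one place: a group of 9 heavy atoms (7 carbon, 2 nitrogen; one six-membered aromatic ring of carbon only) in place of a group of 8 heavy atoms (4 carbon, 1 nitrogen, 3 oxygen; no ring), on a double-bonded ring carbon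

Going by the values given here, the step that bears most directly on this change is the one from compound 2 to compound 3, where a group holding a six-membered aromatic ring of carbon only was replaced by the oxygen-rich chain and the number rose by a number 24.7 percentage points higher from compound 2 to compound 3 (beyond the scatter). Compound 4 moves in the opposite direction, bringing an aromatic ring of carbon only back to the same double-bonded ring carbon, though with two nitrogen atoms rather than one. A fall of similar size is therefore expected in this assay, landing compound 4 among compounds 1 and 2. Compound 4 is estimated at 50%, with a range from 35% to 66%. This estimate means an expected step of a number 21.2 percentage points lower from compound 3 to compound 4 (beyond the scatter).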

Compound 4, a percentage reported as inhibition, in the whole organism at one dose (the size of the read-out at that dose, not a potency): 35.2%
The estimate for compound 4 lay 14.8 percentage points above the measured number, within the range that was stated.
By their numbers in this assay, from the lowest: compounds 4, 1 and 2 (each within the scatter of the next, the first and the last beyond it); then compound 3.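

In this assay, the ((ethoxycarbonyl)carbonyl)amino group of compound 3 now stands clear of a third, quite different group on this double-bonded ring carbon (a number 36 percentage points lower from compound 3 to compound 4 (beyond the scatter)), so compounds 1, 2 and 4 all lie beyond the scatter below it. Going by these compounds alone, the new result also shows, for the first time, that a small change within the aromatic group counts: anilino in place of phenyl on the carbon with a double bond to nitrogen gives a step beyond the scatter (a number 11.3 percentage points lower from compound 2 to compound 4 (beyond the scatter)), whereas compound 4 cannot be told apart from compound 1 (a number 8.7 percentage points lower from compound 1 to compound 4 (within the scatter)). No measurement available here explains why these groups differ.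

As far as these compounds go, it remains open which part of the ((ethoxycarbonyl)carbonyl)amino group goes with the high number, and a carboxylic acid in place of the ethyl ester, or a plain acetyl group on that amine nitrogen, would help to separate its parts. From the compounds shown here alone, since each number comes from a single dose at a single time, how these compounds would rank at other doses also remains open.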